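Replacing the Side Chain on a Ring Nitrogen of Compound 1

The source may report more compounds than this note shows. Statements on the series, on what has been measured and on what is new or still open speak of the compounds shown alone.

Compound 1 `CCOC(=O)C1=Cc2ccccc2OC1(OCc1cn(CC(=O)NC2CCCCC2)nn1)C(F)(F)F` was tested in a functional assay on A549 cells (Homo sapiens) for inhibition, read by MTT assay, with a stated time of 24 h (on this read-out higher numbers stand for weaker inhibition and lower numbers for stronger inhibition), where compound 1 gives 9900 nM. Compound 2 `Cc1ccc(-c2cc(COC3(C(F)(F)F)Oc4ccccc4C=C3C(=O)O)on2)cc1` gives 51200 nM in this assay, so compound 1 stands lowest of the two numbers measured. Compound 3 `O=C(O)C1=Cc2ccccc2OC1(OCc1cc(-c2ccc([N+](=O)[O-])cc2)no1)C(F)(F)F` reaches only a limit of the assay, > 150000 nM. For the measured compounds named here, the single measured step, an at least 2.9-fold higher number from compound 2 to compound 3 (0.46 log units; beyond the scatter), is the only guide, and it weakened inhibition. Compound 4 `CCOC(=O)C1=Cc2ccccc2OC1(OCc1cn(-c2ccc([N+](=O)[O-])cc2)nn1)C(F)(F)F` differs from compound 1 by 4-nitrophenyl in place of (cyclohexylcarbamoyl)methyl on an aromatic nitrogen. The entering group again carries a nitro, though on a different part of the molecule, so a modest weakening or no shift beyond the scatter is expected. Compound 4 is estimated at 20000 nM, between 6000 nM and 80000 nM. That expectation means a step of a 2.0-fold higher number from compound 1 to compound 4 (0.31 log units; beyond the scatter).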

Compound 4, half-maximal inhibitory concentration: > 150000 nM
Compound 4 was reported as a limit; the forecaster's own chance of this, stated with the estimate: 15%; at least 7.5-fold (0.87 log units) between middle value and limit.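

In this assay, for the compounds shown here, the first measured change on this ring nitrogen has a large effect: 4-nitrophenyl in place of (cyclohexylcarbamoyl)methyl gives an at least 15-fold higher number from compound 1 to compound 4 (1.18 log units; beyond the scatter). The side chain here therefore matters strongly for this read-out, while the core of compound 1 stays the same. The full size of the step stays unknown, because compound 4 gives only a limit of the assay: the limit of > 150000 nM in this assay, at which 2 of the 4 values shown sit.

As far as these compounds go, what remains open is whether the loss follows from removing (cyclohexylcarbamoyl)methyl or from introducing the nitro group. A plain phenyl or an aminophenyl group on this nitrogen would help separate these two possibilities.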